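Aryl variation on the saturated ring carbon

The source may hold more compounds than are shown below. What is called first, only, known or untested is meant among the compounds shown, and "the series" means these compounds.

For the measured compounds named here, compound 3 `COc1cc(N2C(N)=C(C#N)C(/C=C/c3ccccc3)C3=C2CC(C)(C)CC3=O)cc(OC)c1OC` is reported as "not active" (no number reported) in a functional assay on Ehrlich cells (Mus musculus) for cytotoxicity (a lower number here means a stronger inhibitor, a higher number a weaker inhibitor), with no number behind it, so it provides no anchor for a step. Compound 1 `COc1ccccc1C1C(C#N)=C(N)N(c2cc(OC)c(OC)c(OC)c2)C2=C1C(=O)CC(C)(C)C2` gives 26600 nM in this assay, and compound 2 `COc1cc(N2C(N)=C(C#N)C(c3ccc(O)cc3)C3=C2CC(C)(C)CC3=O)cc(OC)c1OC` gives 75800 nM. Going by the values given here, the single measured step, a 2.8-fold higher number from compound 1 to compound 2 (0.45 log units; beyond the scatter), is the only comparison of aryl groups on a saturated ring carbon available. Compound 4 `COc1ccc(C2C(C#N)=C(N)N(c3cc(OC)c(OC)c(OC)c3)C3=C2C(=O)CC(C)(C)C3)cc1` differs from compound 3 by 4-methoxyphenyl in place of 2-phenylethenyl on a saturated ring carbon. Among the compounds with values here, no measured step bears directly on this change, as compound 3 lacks a number; the two measured aryl compounds bracket the plausible range, and a value between them seems likely. Compound 4 is expected to give about 45000 nM in this assay, with a range from 15000 nM to 150000 nM.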

Compound 4, half-maximal inhibitory concentration: "not active" (no number reported)
Nothing numeric was reported for compound 4; the estimate stays without a comparison.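

Compound 3 and compound 4 are both reported as "not active" in this assay without a number, so no new step can be read, and no evidence on file bears on this result. The compounds shown leave open how far 4-methoxyphenyl and 2-phenylethenyl on the saturated ring carbon actually differ.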